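Methyl to Chlorophenyl: Expected Gain in Cytotoxic Potency

The source may hold more compounds than are shown below. What is called first, only, known or untested is meant among the compounds shown, and "the series" means these compounds.

The shared core of compound 1 `Cc1nc(-c2c[nH]c3ccccc23)co1` carries a methyl group. In a functional assay on PC-3 cells (Homo sapiens) for cytotoxicity, read by MTT assay, with a stated time of 48 h (on this read-out lower numbers stand for stronger inhibition and higher numbers for weaker inhibition), compound 1 gives 337000 nM, the highest number among the three compounds measured. Compound 3 `C(=C/c1nc(-c2c[nH]c3ccccc23)co1)\c1ccccc1` gives 221000 nM, a value within the scatter of compound 1, so no order between the two can be claimed. Compound 2 `Fc1ccc(-c2nc(-c3c[nH]c4ccccc34)co2)cc1` gives 42800 nM; the step of a 7.9-fold lower number from compound 1 to compound 2 (0.90 log units; beyond the scatter) is the only measured one that bears on the change now in view. Compound 4 `Clc1ccc(-c2nc(-c3c[nH]c4ccccc34)co2)cc1` differs from compound 1 as follows: 4-chlorophenyl in place of methyl on an aromatic carbon. Compound 4 thus differs from compound 2 only by chlorine in place of fluorine, so the step to compound 2 is the closest guide. Because of a 7.9-fold lower number from compound 1 to compound 2 (0.90 log units; beyond the scatter), a drop of similar size, meaning stronger inhibition, is expected for compound 4 in this assay. Compound 4 is therefore estimated at 30000 nM, with a range from 8000 nM to 120000 nM. This estimate means an expected 11-fold lower number from compound 1 to compound 4 (1.05 log units; beyond the scatter).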

Compound 4, half-maximal inhibitory concentration: 151000 nM
Compound 4: the middle estimate sits 5.0-fold (0.70 log units) below what was measured; measured number outside the range, above it.
By their numbers in this assay, from the lowest: compound 2; then compounds 4, 3 and 1 (each within the scatter of the next, the first and the last beyond it).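

In this assay, replacing methyl with 4-chlorophenyl still gives a 2.2-fold lower number from compound 1 to compound 4 (0.35 log units; beyond the scatter), so the lower number seen with 4-fluorophenyl is not unique to that group. The halogen on the added ring also matters: changing only fluoro to chloro gives a 3.5-fold higher number from compound 2 to compound 4 (0.55 log units; beyond the scatter), which shows that adding the six-membered aromatic ring does not alone set the size of the gain at this position. Nothing shown here explains why chloro and fluoro differ in this way.

Going by these compounds, it remains open whether a plain phenyl, a 4-methoxyphenyl or a 4-aminophenyl group at the same place would give a number closer to that of compound 2 or compound 4. It is also unclear whether the order of these two halogens would hold on another cell line.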